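Methyl on the Core: Projecting Compound 4 from Compound 1

The source may report more compounds than this note shows. Statements on the series, on what has been measured and on what is new or still open speak of the compounds shown alone.

Measured so far:
compound 1 `N/C(=N\NC(=S)N1CCCCCC1)c1ccccn1` — 86.5%
compound 2 `N/C(=N\NC(=S)N1CCSCC1)c1ccccn1` — 83.9%
compound 3 `Cc1cccc(/C(N)=N/NC(=S)N2CCCCC2)n1` — 76.4%

In a functional assay on A-375 cells (Homo sapiens) for cytotoxicity, read by MTT assay, with a stated time of 72 h, tested at 10 uM (a lower number here means less inhibition of growth, a higher number more inhibition of growth at the concentration tested), compound 1 gives 86.5%, the top of the three numbers, with compound 2 within the scatter of it and compound 3 beyond it. Compound 4 `Cc1ccnc(/C(N)=N/NC(=S)N2CCCCCC2)c1` differs from compound 1 by methyl in place of hydrogen on an aromatic carbon, meta to a large group and opposite the ring nitrogen. Among the measured compounds shown here, no pair of measured compounds isolates such a change. Since compound 3, which also carries a methyl on the shared core, gives 76.4%, a modest downward step is expected, likely not beyond the scatter. The expected step is a number 5.5 percentage points lower from compound 1 to compound 4 (within the scatter). Compound 4 is thus estimated at 81%, within 67% to 92%.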

Compound 4, percent growth inhibition at one concentration: 70.6%
The estimate for compound 4 lay 10.4 percentage points above the measured number; low and high end bracket the measured number.
By their numbers in this assay, from the lowest: compounds 4, 3, 2 and 1 (each within the scatter of the next, the first and the last beyond it).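

In this assay, among the compounds shown here, the pair gives the first isolated reading of methyl in place of hydrogen on an aromatic carbon, meta to a large group and opposite the ring nitrogen: a number 15.9 percentage points lower from compound 1 to compound 4 (beyond the scatter). This single change at this position is enough to move the number beyond the scatter. No measurement bears on why the number falls. Going by these compounds, whether an ethyl group or an amine at this position would lower the number as far remains open, as does whether the same methyl would give a similar step on compound 2.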